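This account rests on a few compounds, and the source may have more. Where it says the series, first, only, none or still open, it means among the compounds named here.

Three compounds share one core, and each was tested in an assay on a protein complex for inhibition of ubiquitin carboxyl-terminal hydrolase 1/WD repeat-containing protein 48 (Homo sapiens), read by fluorescence; a lower number here means a stronger inhibitor, a higher number a weaker inhibitor. Compound 1 `FC(F)(F)c1ccccc1-c1nc(NCc2ccc(Cl)cc2)c2ccccc2n1` gives 4800 nM. Among the measured compounds shown here, compound 2 `FC(F)(F)c1ccccc1-c1nc(NCc2ccc(-c3ccc(Cl)c(Cl)c3)cc2)c2ccccc2n1` gives 2200 nM, with 3,4-dichlorophenyl in place of chloro as the only change. As a step, a 2.2-fold lower number from compound 1 to compound 2 (0.34 log units; beyond the scatter). Compound 3 `CCc1ccccc1-c1nc(NCc2ccc(-c3cccnc3)cc2)c2ccccc2n1` gives 780 nM, the lowest of the three numbers; its gaps to compound 2 and to compound 1 both lie beyond the scatter.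

Compound 4 `Clc1ccccc1-c1nc(NCc2ccc(-c3cccnc3)cc2)c2ccccc2n1` has not yet been measured. It differs from compound 3 in one place: chloro in place of ethyl on an aromatic carbon. For the measured compounds named here, no measured step bears on this change, since the single measured step alters a different group. Compounds 1 and 2 carry trifluoromethyl where compound 3 carries ethyl, but they differ from compound 3 elsewhere as well, so their values show nothing clean about this group alone. With no measured guide, the step is expected to be small, and a 1.1-fold higher number from compound 3 to compound 4 (0.04 log units; within the scatter) is the estimate, nothing beyond the scatter. Compound 4 is therefore expected to give about 850 nM, in a range from 300 nM to 2500 nM.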

Compound 4, half-maximal inhibitory concentration: 2100 nM
Compound 4: middle estimate off by 2.5-fold (0.39 log units), on the low side; low and high end bracket the measured number.
By their numbers in this assay, from the lowest: compound 3; then compounds 4 and 2 (each within the scatter of the next); then compound 1.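

In this assay, chloro in place of ethyl on this aromatic carbon, ortho to a large group, gives a 2.7-fold higher number from compound 3 to compound 4 (0.43 log units; beyond the scatter) with the rest of the molecule unchanged. Among the compounds shown here, this is the first clean reading of this position, and it shows that the number responds to which small group sits there, with ethyl the better of the two groups compared. The change from 2-ethylphenyl to 2-chlorophenyl therefore cannot be treated as interchangeable in this series, although nothing measured here explains the rise.

As far as these compounds go, whether a methoxy group, an amine or a longer chain such as propyl at this position would lower the number further remains open. How trifluoromethyl ranks against ethyl and chloro is also unsettled, as compounds 1 and 2 carry it but differ elsewhere too.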